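The source may report more compounds than this note shows. Statements on the series, on what has been measured and on what is new or still open speak of the compounds shown alone.

Compound 2 `Nc1c(C(=O)NC2CCCC2)oc2nc(-c3cccs3)cc(C(F)(F)F)c12` carries a cyclopentyl group on the amide-type nitrogen of the shared core, which compound 1 `CNC(=O)c1oc2nc(-c3cccs3)cc(C(F)(F)F)c2c1N` bears as a methyl. In a functional assay on HepG2 cells (Homo sapiens) for antiproliferative activity, read by MTT assay (a lower number here means a stronger inhibitor, a higher number a weaker inhibitor), compound 1 gives 12300 nM, and in this assay compound 2 gives 20800 nM, the highest of the two numbers recorded; the change a 1.7-fold higher number from compound 1 to compound 2 (0.23 log units; within the scatter) is within the scatter. Compound 3 `CCCNC(=O)c1oc2nc(-c3cccs3)cc(C(F)(F)F)c2c1N` is not yet measured in this assay. It differs from compound 2 in one place: propyl in place of cyclopentyl on an amide-type nitrogen. Among the compounds with values here, the only measured step that bears on this change is the one from methyl to cyclopentyl at the same nitrogen, a 1.7-fold higher number from compound 1 to compound 2 (0.23 log units; within the scatter), which did not move the number beyond the scatter, and propyl sits between methyl and cyclopentyl in heavy-atom count. A step of no more than the scatter is therefore expected for a 1.3-fold lower number from compound 2 to compound 3 (0.11 log units; within the scatter). Compound 3 is accordingly estimated at 16000 nM, with a range from 7000 nM to 36000 nM.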

Compound 3, half-maximal inhibitory concentration: 17200 nM
The estimate for compound 3 lay 1.1-fold (0.03 log units) below the measured number; the measured number falls inside the stated range.
By their numbers in this assay, from the lowest: compounds 1, 3 and 2 (each within the scatter of the next).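

In this assay, replacing the cyclopentyl ring with an open propyl chain on the amide-type nitrogen gives a 1.2-fold lower number from compound 2 to compound 3 (0.08 log units; within the scatter), and going from methyl to propyl at the same nitrogen gives a 1.4-fold higher number from compound 1 to compound 3 (0.15 log units; within the scatter). The earlier step changed both the size of the group and the presence of a ring at once; these two steps show that neither the ring nor the added carbons alone moves the number beyond the scatter, so methyl, propyl and cyclopentyl cannot be told apart here. Nothing available explains this flat result.

From the compounds shown here alone, all three groups contain carbon only, so it remains open whether a terminal amine, a carboxylic acid or a phenyl ring on this nitrogen would shift the number. A much longer chain is equally untested among the compounds shown.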